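Estimating compound 4 after a carbonyl enters

This account rests on a few compounds, and the source may have more. Where it says the series, first, only, none or still open, it means among the compounds named here.

Three relatives share one core and differ in the aromatic group on an amine nitrogen. In a functional assay on A549 cells (Homo sapiens) for antiproliferative activity, read by MTT assay, with a stated time of 24 h (on this read-out lower numbers stand for stronger inhibition and higher numbers for weaker inhibition), compound 3 `O=C(NNc1ccccc1F)c1cccc(NS(=O)(=O)c2cnc(O)nc2O)c1` gives 11100 nM and compound 2 `O=C(NNc1cccc(Cl)c1)c1cccc(NS(=O)(=O)c2cnc(O)nc2O)c1` gives 6640 nM. The gap between them, a 1.7-fold higher number from compound 2 to compound 3 (0.22 log units; within the scatter), lies within the scatter, so the two stand level. Compound 1 `Cc1cccc(NNC(=O)c2cccc(NS(=O)(=O)c3cnc(O)nc3O)c2)c1` reports only a limit, > 20000 nM.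

The next compound, compound 4 `Cc1ccccc1C(=O)NNC(=O)c1cccc(NS(=O)(=O)c2cnc(O)nc2O)c1`, carries a new kind of change: (2-methylphenyl)carbonyl in place of 2-fluorophenyl on an amine nitrogen. In words, this is (2-methylphenyl)carbonyl in place of 2-fluorophenyl on an amine nitrogen. The measured steps bear on it only loosely, since none of them brings a carbonyl to that nitrogen. One, an at least 3.0-fold lower number from compound 1 to compound 2 (0.47 log units; beyond the scatter), goes beyond the scatter, while the floor of the other, an at least 1.8-fold lower number from compound 1 to compound 3 (0.25 log units; that floor lies within the scatter), stays within it. The expectation therefore rests mainly on compound 3 at 11100 nM, with no clear shift in this assay and only a slight lean towards a higher number. The expected step is a 1.4-fold higher number from compound 3 to compound 4 (0.13 log units; within the scatter), which stays within the scatter. For compound 4 the estimated value is 15000 nM, with an expected range of 5000 nM to 40000 nM.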

Compound 4, half-maximal inhibitory concentration: 8010 nM
Compound 4: the middle estimate sits 1.9-fold (0.27 log units) above what was measured, within the range that was stated.
By their numbers in this assay, from the lowest: compounds 2, 4 and 3 (each within the scatter of the next). At a limit, above all of these: compound 1.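

Swapping 2-fluorophenyl or 3-chlorophenyl for (2-methylphenyl)carbonyl on this amine nitrogen leaves compound 4 level with both parents in this assay (a 1.4-fold lower number from compound 3 to compound 4 (0.14 log units; within the scatter); a 1.2-fold higher number from compound 2 to compound 4 (0.08 log units; within the scatter)). So this nitrogen can carry a carbonyl-linked aromatic group as well as a directly attached one, with no step beyond the scatter among these three compounds. Within the data shown here, the one step beyond the scatter (an at least 2.4-fold lower number from compound 1 to compound 4 (0.39 log units; beyond the scatter)) gives only a floor, since one end of it is a limit and not a number: the limit of > 20000 nM in this assay, at which 1 of the 4 values shown sits.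

Compound 4 differs from compound 3 in both the carbonyl and the ring substituent, so the carbonyl's own contribution cannot be separated out. A (2-fluorophenyl)carbonyl group would pull these apart, while a cyclohexylcarbonyl group or a short alkyl chain would test whether an aromatic ring is needed here at all.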